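The source may hold more compounds than are shown below. What is called first, only, known or untested is meant among the compounds shown, and "the series" means these compounds.

Measured so far in an assay on isolated protein for inhibition of ubiquitin carboxyl-terminal hydrolase 7 (Homo sapiens), with stated times of 30 min and 2 h; on this read-out higher numbers stand for weaker inhibition and lower numbers for stronger inhibition:
compound 1 `CCCNCc1ccc(-c2c3ncn(CC4(O)CCN(Cc5ccc(-c6ccco6)cc5Cl)CC4)c(=O)c3nn2C)cc1` – 43.9 nM
compound 2 `CC(=O)NCc1ccc(-c2c3ncn(CC4(O)CCN(Cc5ccc(-c6ccco6)cc5Cl)CC4)c(=O)c3nn2C)cc1` – 46.1 nM

Compound 2 and compound 1 stand level with each other in this assay: the step of a 1.1-fold higher number from compound 1 to compound 2 (0.02 log units; within the scatter) lies within the scatter, so the two numbers cannot be told apart.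

Compound 3 `Cn1nc2c(=O)n(CC3(O)CCN(Cc4ccc(-c5ccco5)cc4Cl)CC3)cnc2c1-c1ccc(CN)cc1` differs from compound 2 in one place: hydrogen in place of acetyl on an amine nitrogen, that is, acetamidomethyl becomes aminomethyl. For the measured compounds named here, the only measured step that bears on this position is a 1.1-fold higher number from compound 1 to compound 2 (0.02 log units; within the scatter), which shows that exchanging propyl for acetyl on that amine nitrogen made no difference beyond the scatter. Going by the values given here, no measured compound carries the bare amine, so the data give no direct anchor for compound 3. On this basis the expected step is a 1.1-fold higher number from compound 2 to compound 3 (0.04 log units; within the scatter), no change beyond the scatter, with the range widened for the unanchored change. Compound 3 is estimated at 50 nM, between 18 nM and 140 nM.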

Compound 3, half-maximal inhibitory concentration: 18.1 nM
Beside the measured number, compound 3's estimate is 2.8-fold (0.44 log units) above it; the measured number falls inside the stated range.
By their numbers in this assay, from the lowest: compound 3; then compounds 1 and 2 (each within the scatter of the next).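

Notes on the amine nitrogen of the 4-(aminomethyl)phenyl group: in this assay the bare amine separates from both substituted forms, with a 2.5-fold lower number from compound 2 to compound 3 (0.41 log units; beyond the scatter) on losing acetyl and a 2.4-fold lower number from compound 1 to compound 3 (0.38 log units; beyond the scatter) on losing propyl. Compounds 1 and 2 stood level and made this nitrogen look indifferent to its substituent, but compound 3 shows that hydrogen there gives modestly stronger inhibition than either acetyl or propyl. No measurement on hand explains this gain.

Still open, as far as these compounds go, is whether a single methyl or ethyl group on this nitrogen stays with compound 3 or falls level with compounds 1 and 2. Also open, from the compounds shown here alone, is whether a dimethylamino group, a longer chain between the amine and the phenyl ring, or a carboxylic acid in place of the amine would keep the gain.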